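Changing the Aryl Group on the Sulfonyl Sulfur

This account rests on a few compounds, and the source may have more. Where it says the series, first, only, none or still open, it means among the compounds named here.

Compound 1, `Cn1c(=O)c(S(=O)(=O)c2ccc(F)cc2F)cc2cnc(Nc3ccc4[nH]c(C(=O)O)cc4c3)nc21`, gives 10000 nM in a functional assay on DU-145 cells (Homo sapiens) for inhibition, read by trypan blue exclusion, with a stated time of 72 h; on this read-out higher numbers stand for weaker inhibition and lower numbers for stronger inhibition.
Compound 2, `Cn1c(=O)c(S(=O)(=O)c2ccc(F)cc2F)cc2cnc(Nc3cccc4[nH]ccc34)nc21`, gives 750 nM in this assay.
Compound 3, `Cc1cc2cc(Nc3ncc4cc(S(=O)(=O)c5ccc(F)cc5F)c(=O)n(C)c4n3)ccc2[nH]1`, gives 750 nM in this assay.

Compound 2 stands level with compound 3 at the digits shown, and the two share the lowest number of the three. Compound 1 is the outlier: a 13-fold lower number from compound 1 to compound 2 (1.12 log units; beyond the scatter) and a 13-fold lower number from compound 1 to compound 3 (1.12 log units; beyond the scatter), while no change at the digits printed from compound 2 to compound 3 (within the scatter). Every one of these steps alters the indole-bearing amine side of the shared core and leaves the sulfonyl side untouched.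

Compound 4, `Cc1ccc(S(=O)(=O)c2cc3cnc(Nc4cccc5[nH]ccc45)nc3n(C)c2=O)cc1`, is not yet measured. It differs from compound 2 at the opposite end of the molecule: 4-methylphenyl in place of 2,4-difluorophenyl on a sulfonyl sulfur. For the measured compounds named here, no measured pair varies this part of the structure, so the three known steps give no direct guidance on its size or direction. In the absence of such evidence, the best expectation is that compound 4 stays close to compound 2, with a 1.2-fold higher number from compound 2 to compound 4 (0.08 log units; within the scatter). Compound 4 is therefore estimated at 900 nM in this assay, within a range of 300 nM to 3000 nM, the width reflecting how little the measured compounds say about this position.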

Compound 4, half-maximal inhibitory concentration: 10000 nM
Compound 4: the middle estimate sits 11-fold (1.05 log units) below what was measured, outside the stated range (above it).
By their numbers in this assay, from the lowest: compounds 2 and 3 (each within the scatter of the next); then compounds 1 and 4 (each within the scatter of the next).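

The group on the sulfonyl sulfur turns out to matter a great deal: in this assay, 4-methylphenyl in place of 2,4-difluorophenyl gives a 13-fold higher number from compound 2 to compound 4 (1.12 log units; beyond the scatter), and on this read-out that higher number means weaker inhibition. For the compounds shown here, until now, every measured step changed the amine side of the shared core, so this is the first evidence that the sulfonyl side can shift the number just as clearly. The counts do not separate the two groups, since each is a single six-membered aromatic ring of carbon only, with no hydrogen-bond donors or acceptors and no net charge, and nothing available explains why the swap weakens inhibition.

This one step removes two fluorines and adds a methyl at once, so it cannot show whether losing the fluorines, gaining the methyl, or both account for the change; plain phenyl and 4-fluorophenyl on the sulfonyl sulfur would help to pull these apart. On these data alone, it also remains open whether the same swap has a similar effect when the amine side carries 2-methyl-1H-indol-5-yl instead of 1H-indol-4-yl.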